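The source may hold more compounds than are shown below. What is called first, only, known or untested is meant among the compounds shown, and "the series" means these compounds.

Compound 2 `Cc1cc(C)c(CN2CCc3c(Cl)cc([C@H](CO)[C@@H]4CCCO4)c(Cl)c3C2=O)c(=O)[nH]1` is the more weakly inhibiting of the two compounds with a single number in a functional assay on KARPAS-422 cells (Homo sapiens) for antiproliferative activity, read by resazurin assay, with a stated time of 72 h; on this read-out lower numbers stand for stronger inhibition and higher numbers for weaker inhibition: compound 2 gives 57 nM, while compound 1 `Cc1cc(C)c(CN2CCc3c(Cl)cc(-c4c(C)noc4C)c(Cl)c3C2=O)c(=O)[nH]1` gives 23 nM, a step of a 2.5-fold higher number from compound 1 to compound 2 (0.39 log units; beyond the scatter). Compound 3 `COC(c1cc(Cl)c2c(c1Cl)C(=O)N(Cc1c(C)cc(C)[nH]c1=O)CC2)C1CCOC1` has several entries, 175 nM; 406 nM; 50 nM; 25 nM (4 entries), whose spread the several entries of compound 3 in this assay, 175 nM; 406 nM; 50 nM; 25 nM (4 entries) shows how far repeats of this assay can fall apart. Compound 4 `Cc1cc(C)c(CN2CCc3c(Cl)cc([C@H](CO)[C@H]4CCCO4)c(Cl)c3C2=O)c(=O)[nH]1` differs from compound 2 in this way: the two compounds have the same atoms and bonds and differ only in configuration as drawn: 1 of 2 stereo elements differ; a stereocentre at a saturated ring carbon is drawn S in compound 2 and R in compound 4. Among the compounds with values here, no measured step involves a change of configuration alone, so none bears directly on this one. The expectation for compound 4 is therefore set near compound 2, with the step from compound 2 to compound 4 expected as a 1.4-fold higher number from compound 2 to compound 4 (0.15 log units; within the scatter). Compound 4 is estimated at 80 nM, within 25 nM to 300 nM.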

Compound 4, half-maximal inhibitory concentration: 63 nM
For compound 4 the middle estimate is 1.3-fold (0.10 log units) above the measured one; the range from low to high includes it.
By their numbers in this assay, from the lowest: compound 1; then compounds 2 and 4 (each within the scatter of the next).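

The earlier compounds shown here held no change of configuration alone; at this saturated ring carbon, in this assay, drawing the stereocentre R rather than S gives a 1.1-fold higher number from compound 2 to compound 4 (0.04 log units; within the scatter), so the two configurations cannot be told apart here. Replacing the five-membered aromatic ring group remains a modest change with the R configuration too, at a 2.7-fold higher number from compound 1 to compound 4 (0.44 log units; beyond the scatter). Small gaps in this assay need caution, given how far repeats can fall apart: the several entries of compound 3 in this assay, 175 nM; 406 nM; 50 nM; 25 nM (4 entries)

The compounds shown leave open whether the second stereocentre, drawn alike in compound 2 and compound 4, affects the number. They also leave open how an amine or a carboxylic acid in place of the alcohol would read.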